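Dimethylamino to diethylamino on two cores

This account rests on a few compounds, and the source may have more. Where it says the series, first, only, none or still open, it means among the compounds named here.

Compound 1 `CN(C)CCCn1c(N)c(-c2nc3ccccc3[nH]2)c2nc(C#N)c(C#N)nc21` and compound 2 `CCN(CC)CCCn1c(N)c(-c2nc3ccccc3[nH]2)c2nc(C#N)c(C#N)nc21` share one core; compound 3 `CN(C)CCCCn1c(N)c(-c2nc3ccccc3o2)c2nc(C#N)c(C#N)nc21` and compound 4 `CCN(CC)CCCCn1c(N)c(-c2nc3ccccc3o2)c2nc(C#N)c(C#N)nc21` share another, and the difference between the two cores is not broken down here. In a functional assay on Raji cells (Homo sapiens) for antiproliferative activity, read by MTT assay, with a stated time of 48 h (a lower number here means a stronger inhibitor, a higher number a weaker inhibitor), compound 1 gives 1230 nM, and compound 2 gives 1870 nM. The change between them, (diethylamino in place of dimethylamino on a saturated chain carbon, three bonds along the chain from an aromatic nitrogen), gave a 1.5-fold higher number from compound 1 to compound 2 (0.18 log units; within the scatter). Compound 3 gives 9200 nM in this assay, the highest number of the three measured, standing beyond the scatter from both compound 1 and compound 2. Compound 4 carries the same kind of change on the second core, (diethylamino in place of dimethylamino on a saturated chain carbon, four bonds along the chain from an aromatic nitrogen); the two places differ only in that the saturated chain carbon sits four bonds rather than three bonds along the chain from the aromatic nitrogen. The change has been seen once, on the first core, and the expectation for compound 4 rests on that single step alone. From compound 3 to compound 4 a step of about a 1.4-fold higher number from compound 3 to compound 4 (0.15 log units; within the scatter) is expected in this assay. Compound 4 is thus estimated at 13000 nM, with a range from 6500 nM to 28000 nM.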

Compound 4, half-maximal inhibitory concentration: 2610 nM
Beside the measured number, compound 4's estimate is 5.0-fold (0.70 log units) above it; measured number outside the range, below it.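

On the second core, diethylamino in place of dimethylamino gives a 3.5-fold lower number from compound 3 to compound 4 (0.55 log units; beyond the scatter) in this assay. The change therefore cannot be carried from the first core to the second as a step of fixed size or direction: the same change on two cores in this assay, a 1.5-fold higher number (0.18 log units; within the scatter) from compound 1 to compound 2 and a 3.5-fold lower number (0.55 log units; beyond the scatter) from compound 3 to compound 4, 5.4-fold (0.73 log units) apart, beyond the scatter of two such steps

This does not show which part of the difference between the two pairs accounts for the gap, since the place of the change, four bonds rather than three along the chain from the aromatic nitrogen, varies together with the rest of the core, and two pairs give no rule for any further core.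

Still open, on these data alone, is whether the step follows the chain or the rest of the core, a question that a three-bond chain on the second core or a four-bond chain on the first would address. Also open, as far as these compounds go, is how a cyclic amine such as piperidine or morpholine, or a longer chain, would read in place of these amines on either core.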